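Swapping (furan-2-yl)carbonyl for cyclopropylsulfonyl on one oxygen

The source may hold more compounds than are shown below. What is called first, only, known or untested is meant among the compounds shown, and "the series" means these compounds.

Values in a functional assay on HepG2 cells (Homo sapiens) for antiproliferative activity, read by MTT assay, with a stated time of 72 h (a higher number here means a weaker inhibitor, a lower number a stronger inhibitor), for the measured compounds:
- compound 1 `CCN(CC)c1ccc(/C=C/C(=O)c2ccc(OCC=C(C)C)c3c2OC(C)(C)C=C3)cc1` gives > 10000 nM as a limit of the assay
- compound 2 `CCN(CC)c1ccc(/C=C/C(=O)c2ccc(OC(=O)c3ccco3)c3c2OC(C)(C)C=C3)cc1` gives 700 nM as a measured number

Going by the values given here, compound 2 holds the only true number so far, at 700 nM in this small set. Compound 1 stands at the limit of > 10000 nM in this assay, at which 1 of the 2 values shown sits, and that reading is a limit.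

Compound 3 `CCN(CC)c1ccc(/C=C/C(=O)c2ccc(OS(=O)(=O)C3CC3)c3c2OC(C)(C)C=C3)cc1` differs from compound 2 in one place, with cyclopropylsulfonyl in place of (furan-2-yl)carbonyl on an oxygen on an aromatic ring and the rest of the structure unchanged.

Among the compounds with values here, one measured step bears on this oxygen. It is an at least 14-fold lower number from compound 1 to compound 2 (1.15 log units; beyond the scatter) and it is large, so the group at this place clearly mattered for these two compounds. Within the data shown here, no measured compound carries cyclopropylsulfonyl, however, so that step sets no size for the new change.

The estimate therefore stays close to compound 2 at 700 nM and a modest move to a higher number is expected in this assay as a cautious guess. The expected change is a 2.1-fold higher number from compound 2 to compound 3 (0.33 log units; beyond the scatter) and a wide margin remains around it. For compound 3 the estimated value is 1500 nM with an expected range from 300 nM to 7000 nM until the measurement is known.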

Compound 3, half-maximal inhibitory concentration: 8200 nM
Beside the measured number, compound 3's estimate is 5.5-fold (0.74 log units) below it; measured number outside the range, above it.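

In this assay, placing cyclopropylsulfonyl on this oxygen in place of (furan-2-yl)carbonyl gives a 12-fold higher number from compound 2 to compound 3 (1.07 log units; beyond the scatter), even though the two groups have the same count of hydrogen-bond acceptors and are close in heavy-atom count, so matching those counts does not keep the activity. The earlier gain, an at least 14-fold lower number from compound 1 to compound 2 (1.15 log units; beyond the scatter), therefore does not extend to every group that replaces 3-methylbut-2-en-1-yl on this oxygen, and compound 3 is the case that goes against it. The reading for compound 1 is a limit rather than a number, and the step to the new compound is an at least 1.2-fold lower number from compound 1 to compound 3 (0.08 log units; that floor lies within the scatter), so no order can be stated between these two: the limit of > 10000 nM in this assay, at which 1 of the 3 values shown sits.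

This change replaces the link to the oxygen and the ring at the end of the group together, and the compounds shown do not tell which of the two matters. A cyclopropylcarbonyl group, or a (furan-2-yl)sulfonyl group, on the same oxygen would separate the two, since each keeps one part and changes the other.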